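Sulfonyl group exchange from compound 2 to compound 3

The compounds below may be only part of what the source reports. "The series", "measured", "known", "first", "only" and "open" are said of these compounds alone.

Measured so far in an ADME assay on BJ cells (Homo sapiens) for antiproliferative activity, with a stated time of 72 h; on this read-out lower numbers stand for an effect already at smaller amounts and higher numbers for an effect only at larger amounts of compound:
- compound 1 `COc1ccc(-c2cc(=O)c3c(OC)cc(OC)cc3n2C)cc1`: 68000 nM
- compound 2 `COc1ccc(-c2cc(=O)c3c(OC)cc(OC)cc3n2S(=O)(=O)c2cc(Cl)cc(Cl)c2O)cc1`: > 37900 nM (a limit of the assay, not a number)

Compound 2 stands at > 37900 nM, which is a limit of the assay and not a number. Going by the values given here, compound 1 supplies the only actual number, 68000 nM.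

Compound 3 `COc1ccc(-c2cc(=O)c3c(OC)cc(OC)cc3n2S(=O)(=O)c2ccc(Br)s2)cc1` carries 5-bromothiophen-2-yl in place of 3,5-dichloro-2-hydroxyphenyl on a sulfonyl sulfur. Among the compounds with values here, no measured step sizes this exchange in this assay. Within the data shown here, the only further guide is that compound 1 also needs a large amount, 68000 nM. The expected change is none beyond the scatter, with no direction favoured, and the estimated step is a step that the limit leaves unreadable from compound 2 to compound 3. A limit may again be all that is reported. For compound 3 the estimated value is 45000 nM, with an expected range from 15000 nM to 120000 nM.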

Compound 3, half-maximal effective concentration: > 48200 nM
Compound 3 was reported as a limit; the forecaster's own chance of this, stated with the estimate: 50%; at least 1.0-fold (0.02 log units) between middle value and limit.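

No step can be read from compound 2 to compound 3 or from compound 1 to compound 3: in this assay compound 2 and compound 3 are each reported only as a limit of the assay. The compounds shown leave open how 5-bromothiophen-2-yl and 3,5-dichloro-2-hydroxyphenyl on a sulfonyl sulfur compare in this assay, and how either sulfonyl group compares with methyl on an aromatic nitrogen.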